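Trifluoromethyl for methyl on the aryl of compound 1

The compounds below may be only part of what the source reports. "The series", "measured", "known", "first", "only" and "open" are said of these compounds alone.

Compound 1 `CCCCc1cc2ccccc2nc1-c1cc(-c2ccc(C)cc2)no1` stands only at a limit in a functional assay on MDA-MB-231 cells (Homo sapiens) for inhibition, read by MTT assay, with a stated time of 24 h; a lower number here means a stronger inhibitor, a higher number a weaker inhibitor. In this assay compound 1 gives > 100000 nM, which is a limit of the assay and not a number. Compound 2 `CCCCCc1cc2ccccc2nc1-c1cc(-c2ccc(C)cc2)no1` likewise gives > 100000 nM in this assay, again a limit. The step that the two limits leave unreadable from compound 1 to compound 2 cannot be read between the two limits; both values sit at the limit of > 100000 nM in this assay, at which 2 of the 2 values shown sit. Compound 3 `CCCCc1cc2ccccc2nc1-c1cc(-c2ccc(C(F)(F)F)cc2)no1` differs from compound 1 by trifluoromethyl in place of methyl on an aromatic carbon. Among the measured compounds shown here, no measured step bears on this change, and with both measured values at a limit no direction can be read from the series. Compound 3 is therefore expected at 150000 nM (range 30000 nM to 500000 nM), most likely reported again as a limit, the step that the limit leaves unreadable from compound 1 to compound 3 being an estimate only.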

Compound 3, half-maximal inhibitory concentration: 10400 nM
For compound 3 the middle estimate is 14-fold (1.16 log units) above the measured one; measured number outside the range, below it.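

In this assay, among the compounds shown here, the aromatic carbon para to a large group is the first place where a change gives a readable result: trifluoromethyl in place of methyl gives an at least 9.6-fold lower number from compound 1 to compound 3 (0.98 log units; beyond the scatter). That step is a bound and not an exact size, because compound 1 stands at a limit: the limit of > 100000 nM in this assay, at which 2 of the 3 values shown sit. The step between the two chain lengths cannot be read.

On these data alone, whether chlorine or methoxy at this aromatic carbon would do the same stays open. So does the effect of an amine on the chain when trifluoromethyl is present.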